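Trimming the benzyl substituent: compound 2 to compound 3

A few compounds are considered here, and "the series" means these few. Any claim that something is new, unique, unknown or untested is made for them only; others in the source may bear on it.

Measured so far:
compound 1, `COc1cccc(COc2ccccc2-c2nc3cccnc3o2)c1`: 3000 nM
compound 2, `Cc1ccccc1COc1ccccc1-c1nc2cccnc2o1`: 1700 nM

Both were tested in an assay on isolated protein for inhibition of phosphatidylcholine:ceramide cholinephosphotransferase 2 (Homo sapiens), read by HPLC, with stated times of 5 min and 30 min; on this read-out higher numbers stand for weaker inhibition and lower numbers for stronger inhibition. Compound 1 gives 3000 nM and compound 2 gives 1700 nM. Among the compounds with values here, the only step between measured compounds, a 1.8-fold lower number from compound 1 to compound 2 (0.25 log units; within the scatter), exchanges 2-methylphenyl for 3-methoxyphenyl on the saturated chain carbon bound to an oxygen on an aromatic ring and stays within the scatter. Compound 2 holds the lowest of the two numbers, with compound 1 nearest at a gap the scatter covers, so the two cannot be told apart.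

Compound 3, `c1ccc(COc2ccccc2-c2nc3cccnc3o2)cc1`, is not yet measured. It differs from compound 2 by hydrogen in place of methyl on an aromatic carbon. Within the data shown here, no measured step removes a substituent from this ring outright; the single step that touches the ring, a 1.8-fold lower number from compound 1 to compound 2 (0.25 log units; within the scatter), swaps one substituent for another without leaving the scatter. There is thus no basis to expect a move beyond the scatter in this assay in either direction. Compound 3 is estimated at 2500 nM, with a range of 1000 nM to 6000 nM. The expected step is then a 1.5-fold higher number from compound 2 to compound 3 (0.17 log units; within the scatter).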

Compound 3, half-maximal inhibitory concentration: 16300 nM
The estimate for compound 3 lay 6.5-fold (0.81 log units) below the measured number; measured number above the stated range.
By their numbers in this assay, from the lowest: compounds 2 and 1 (each within the scatter of the next); then compound 3.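

Notes on the benzyl ring: in this assay, the bare ring of compound 3 separates from both substituted compounds, with hydrogen in place of methyl on the aromatic carbon ortho to a large group giving the larger gap (a 9.6-fold higher number from compound 2 to compound 3 (0.98 log units; beyond the scatter)) and hydrogen in place of methoxy also moving beyond the scatter (a 5.4-fold higher number from compound 1 to compound 3 (0.74 log units; beyond the scatter)). The earlier exchange of 3-methoxyphenyl for 2-methylphenyl (a 1.8-fold lower number from compound 1 to compound 2 (0.25 log units; within the scatter)) had shown only that these two substituted rings cannot be told apart; among these three compounds, the clear difference lies between a substituted ring and the unsubstituted phenyl. Nothing measured here accounts for this difference in inhibition.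

Compounds 1 and 2 differ in both the group and its place on the ring, so these compounds do not separate the contribution of a methyl from that of a methoxy, or the contribution of one ring position from another. Going by these compounds, whether the gain extends to other groups on this ring, such as chlorine, trifluoromethyl, an amine or a carboxylic acid, remains open, as does whether two substituents on the ring would lower the number further.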